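Methoxy for methyl on the anilide ring of a thiosemicarbazone

The source may hold more compounds than are shown below. What is called first, only, known or untested is meant among the compounds shown, and "the series" means these compounds.

The three measured compounds share one core, seen unsubstituted in compound 1 `NC(=S)N/N=C/c1ccc2ccccc2n1`, which in a functional assay on SGC-7901 cells (Homo sapiens) for antiproliferative activity, read by sulforhodamine B assay, with a stated time of 72 h (on this read-out higher numbers stand for weaker inhibition and lower numbers for stronger inhibition), gives 32700 nM. Compound 2 `COc1cccc(NC(=S)N/N=C/c2ccc3ccccc3n2)c1` gives 79400 nM, and compound 3 `Cc1ccc(NC(=S)N/N=C/c2ccc3ccccc3n2)cc1` gives 92900 nM. Both aryl groups on the thioamide nitrogen raise the number: a 2.4-fold higher number from compound 1 to compound 2 (0.39 log units; beyond the scatter) and a 2.8-fold higher number from compound 1 to compound 3 (0.45 log units; beyond the scatter). Between the two aryl compounds the gap is small, a 1.2-fold higher number from compound 2 to compound 3 (0.07 log units; within the scatter), so compound 3 and compound 2 cannot be told apart on these numbers; only its step from compound 1 is beyond the scatter.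

Compound 4 `COc1ccc(NC(=S)N/N=C/c2ccc3ccccc3n2)cc1` differs from compound 3 by methoxy in place of methyl on an aromatic carbon. For the measured compounds named here, the one step that speaks to this change is the one from compound 2 to compound 3, where a methoxy-bearing ring and a methyl-bearing ring gave numbers within the scatter of each other. Going by the values given here, nothing among the measured compounds shows a methoxy at this place moving the number appreciably. Compound 4 is therefore expected to stay close to compound 3, with a step of about a 1.1-fold lower number from compound 3 to compound 4 (0.04 log units; within the scatter), that is, none beyond the scatter. The estimate for compound 4 in this assay is 85000 nM, with a range from 40000 nM to 180000 nM.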

Compound 4, half-maximal inhibitory concentration: 89600 nM
Compound 4: middle estimate off by 1.1-fold (0.02 log units), on the low side; the measured number falls inside the stated range.
By their numbers in this assay, from the lowest: compound 1; then compounds 2, 4 and 3 (each within the scatter of the next).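

In this assay, for the compounds shown here, methoxy in place of methyl on the aromatic carbon para to a large group gives no readable change, with a 1.0-fold lower number from compound 3 to compound 4 (0.02 log units; within the scatter); this is the first direct comparison of the two groups on the same ring carbon, as the earlier step between compound 2 and compound 3 had changed the whole aryl group. The position of the methoxy group also makes no readable difference between these two compounds, as 4-methoxyphenyl in place of 3-methoxyphenyl on the amide-type nitrogen gives a 1.1-fold higher number from compound 2 to compound 4 (0.05 log units; within the scatter). The only step here beyond the scatter is the one from hydrogen to an aryl group, where 4-methoxyphenyl gives a 2.7-fold higher number from compound 1 to compound 4 (0.44 log units; beyond the scatter), the same direction as for compound 2 and compound 3, so among these four compounds the presence of the aryl group is what separates them, and no compound goes against this.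

The data offer no explanation for either the flat aryl comparisons or the step from hydrogen. On these data alone, it remains open whether an amine or a carboxylic acid on this ring carbon, or a longer chain in place of the aryl group on the nitrogen, would move the number beyond the scatter.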